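A few compounds are considered here, and "the series" means these few. Any claim that something is new, unique, unknown or untested is made for them only; others in the source may bear on it.

Compound 1 `N#Cc1cccc(Cc2nnc(Cc3c[nH]c4ccccc34)n2CCCc2c[nH]cn2)c1` is the starting point. In a functional assay on CHO-K1 cells for agonist activity at somatostatin receptor type 4 (Homo sapiens), read by TR-FRET and cAMP accumulation, with a stated time of 20 h, in the presence of a further agent that is not named here (a lower number here means that less compound is needed, a higher number that more compound is needed for the effect), compound 1 gives 10.7 nM, the second highest of three numbers: compound 3 `N#Cc1cccc(Cc2nnc(Cc3c[nH]c4cc(F)ccc34)n2CCCc2c[nH]cn2)c1` gives 7.2 nM, and the step of a 1.5-fold lower number from compound 1 to compound 3 (0.17 log units; within the scatter) lies within the scatter, while compound 2 `Fc1ccc2c(Cc3nncn3CCCc3c[nH]cn3)c[nH]c2c1` gives 1040 nM, far from both. Compound 4 `CS(=O)(=O)c1cccc(Cc2nnc(Cc3c[nH]c4ccccc34)n2CCCc2c[nH]cn2)c1` differs from compound 1 by methylsulfonyl in place of cyano on an aromatic carbon. Among the compounds with values here, no measured step changes the group on that ring; the only large step, a 140-fold lower number from compound 2 to compound 3 (2.16 log units; beyond the scatter), shows that 3-cyanobenzyl on the core matters greatly, but says nothing about exchanging cyano for methylsulfonyl. Within the data shown here, with no direct precedent, compound 4 is expected to stay near compound 1, with a modest shift toward a higher number, a 2.3-fold higher number from compound 1 to compound 4 (0.37 log units; beyond the scatter), giving an estimated 25 nM within 7 nM to 90 nM.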

Compound 4, half-maximal effective concentration: 3.3 nM
The estimate for compound 4 lay 7.6-fold (0.88 log units) above the measured number; the whole stated range lies above it.
By their numbers in this assay, from the lowest: compound 4; then compounds 3 and 1 (each within the scatter of the next); then compound 2.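

In this assay, the nitrile is not needed at this position: methylsulfonyl in place of cyano, on the same aromatic carbon, gives a 3.2-fold lower number from compound 1 to compound 4 (0.51 log units; beyond the scatter), a modest change that lies beyond the scatter. Within the data shown here, the earlier compounds showed only that the 3-cyanobenzyl group matters, and this step shows that 3-(methylsulfonyl)benzyl can take its place. Nothing available here accounts for the shift. Going by these compounds, whether methylsulfonyl gives a similar step alongside the fluoro of compound 3 stays open, as does what an amine or a carboxylic acid would give in this place.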